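Methoxy on the phenylpiperazine: expected cytotoxicity of compound 4

The compounds below may be only part of what the source reports. "The series", "measured", "known", "first", "only" and "open" are said of these compounds alone.

Compound 1 `O=C(CN1CCN(c2ccccc2)CC1)N1CCN(c2nnc(-c3ccccc3)c(-c3ccccc3)n2)CC1` is the parent of this small series. In an ADME assay on NIH3T3 cells (Mus musculus) for cytotoxicity, read by MTT assay, with a stated time of 24 h (on this read-out lower numbers stand for stronger inhibition and higher numbers for weaker inhibition), compound 1 gives > 963000 nM, which is a limit of the assay rather than a number. Compound 2 `O=C(CN1CCN(c2ccccc2Cl)CC1)N1CCN(c2nnc(-c3ccccc3)c(-c3ccccc3)n2)CC1` carries a chloro group and in this assay gives 350000 nM. For the measured compounds named here, the one measured step is an at least 2.7-fold lower number from compound 1 to compound 2 (0.43 log units; beyond the scatter), so a substituent at that place has moved the number downward at least modestly. Compound 3 `O=C(CN1CCN(c2ccccc2)CC1)N1CCN(c2nnc(-c3ccc(Cl)cc3)c(-c3ccc(Cl)cc3)n2)CC1` carries two chloro groups on the other end of the shared core; in this assay compound 3 gives > 850000 nM, again a limit of the assay rather than a number, and two of the three values shown are such limits. Compound 4 `COc1ccccc1N1CCN(CC(=O)N2CCN(c3nnc(-c4ccc(Cl)cc4)c(-c4ccc(Cl)cc4)n3)CC2)CC1` differs from compound 3 by methoxy in place of hydrogen on an aromatic carbon, a change at the same place as the chloro of compound 2. The step from compound 1 to compound 2 bears on it, and a step of similar size and direction is expected, with an estimated at least 2.1-fold lower number from compound 3 to compound 4 (0.32 log units; beyond the scatter). Compound 4 is therefore expected to give about 400000 nM, within 150000 nM to 1000000 nM.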

Compound 4, half-maximal inhibitory concentration: 405000 nM
Estimate against measurement, compound 4: 1.0-fold (0.01 log units) below; measured number inside the range.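

Methoxy ortho to a large group gives an at least 2.0-fold lower number from compound 3 to compound 4 (0.32 log units; beyond the scatter) in this assay, so the downward move first seen with chloro now appears with a second group and on a core carrying two chloro groups, and no compound shown goes against it. The true size of this step remains unknown because compound 3 stands at a limit of the assay: the limit of > 850000 nM in this assay, at which 1 of the 4 values shown sits. Compound 1 also stands at a limit, so the chloro and methoxy steps cannot be ranked against each other: the limit of > 963000 nM in this assay, at which 1 of the 4 values shown sits.

Going by these compounds, whether an amine or a carboxylic acid at this place would also lower the number remains open. So does whether a longer chain such as ethoxy would do so, and whether methoxy would move the number in the same way on the core of compound 1.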